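Trifluoromethyl for fluoro on the imine aryl ring

The source may report more compounds than this note shows. Statements on the series, on what has been measured and on what is new or still open speak of the compounds shown alone.

Compound 1, `CC1CCC(/C=N/c2ccc(F)cc2)=C2NC=C(C(=O)O)C(=O)N21`: 10.6 umol/kg
Compound 2, `Cc1cccc(/N=C/C2=C3NC=C(C(=O)O)C(=O)N3C(C)CC2)c1`: 0.8 umol/kg

Within the data shown here, in a functional assay on the whole organism with Rattus norvegicus as the target (a higher number here means that more compound is needed for the effect, a lower number that less compound is needed), compound 1 gives 10.6 umol/kg, the highest of the two numbers measured; compound 2 gives 0.8 umol/kg, and the one measured step runs a 13-fold lower number from compound 1 to compound 2 (1.12 log units; beyond the scatter). Compound 3, `CC1CCC(/C=N/c2ccc(C(F)(F)F)cc2)=C2NC=C(C(=O)O)C(=O)N21`, differs from compound 1 in one place: trifluoromethyl in place of fluoro on an aromatic carbon. Among the measured compounds shown here, the step from compound 1 to compound 2 altered the same aromatic ring, but by a different group at a different place, so it shows only that this ring tolerates change and can move the number strongly; no measured step tests a trifluoromethyl directly. The change from compound 1 to compound 3 is therefore expected to give a step of modest size, a 1.5-fold lower number from compound 1 to compound 3 (0.18 log units; within the scatter), likely within the scatter or a slight lowering. Compound 3 is estimated at 7 umol/kg, with a range from 2 umol/kg to 25 umol/kg.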

Compound 3, dose for 50% inhibition: > 100 umol/kg
Compound 3: no number, only a limit; the forecaster's own chance of this, stated with the estimate: 5%; at least 14-fold (1.15 log units) between middle value and limit.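

The step of an at least 9.4-fold higher number from compound 1 to compound 3 (0.97 log units; beyond the scatter) shows that a change at this aromatic carbon, para to a large group, can raise the number in this assay, whereas the earlier step on this ring lowered it. From the compounds shown here alone, compound 3 gives > 100 umol/kg, which is a limit of the assay and not a number, so the full size of the step stays unknown: the limit of > 100 umol/kg in this assay, at which 1 of the 3 values shown sits. At this one carbon, then, fluoro gives a measured dose, while trifluoromethyl gives only a limit.

The compounds shown leave open how a methyl, a chlorine or an amine at this same carbon would read, and so whether the rise belongs to trifluoromethyl alone. They also leave open how a trifluoromethyl would read at the ring carbon that carries the methyl in compound 2.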